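The compounds below may be only part of what the source reports. "The series", "measured", "known", "first", "only" and "open" are said of these compounds alone.

Values in a functional assay on MCF7 cells (Homo sapiens) for antiproliferative activity, read by MTT assay, with a stated time of 48 h; a higher number here means a weaker inhibitor, a lower number a stronger inhibitor:
- compound 1 `CCCCCCCn1cc(COC[C@@H]2OC[C@H](N)[C@@H]2O)nn1`: > 128000 nM (a limit)
- compound 2 `CCCCCCCCCCCCn1cc(COC[C@@H]2OC[C@H](N)[C@@H]2O)nn1`: 2210 nM
- compound 3 `CCCCCCCn1cc(COC[C@@H]2OC[C@H](N)[C@H]2O)nn1`: > 128000 nM (a limit)

Compound 3 gives a limit and no number: it stands at the limit of > 128000 nM in this assay, at which 2 of the 3 values shown sit. Its true position is therefore unread, and any step starting from it can only be approximate.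

Compound 4 `CCCCCCCCCCn1cc(COC[C@@H]2OC[C@H](N)[C@H]2O)nn1` is the next structure to consider. The change is propyl in place of hydrogen on a saturated chain carbon, seven bonds along the chain from an aromatic nitrogen.

Going by the values given here, the closest precedent is an at least 57-fold lower number from compound 1 to compound 2 (1.76 log units; beyond the scatter), a large step beyond the scatter, with pentyl at the same place. Among the compounds with values here, that step was seen only in the configuration of compound 1. The other relevant step, a step that the two limits leave unreadable from compound 1 to compound 3, has no readable size, so it does not show whether the chain effect carries over to the configuration of compound 3.

Following compound 2 and an at least 57-fold lower number from compound 1 to compound 2 (1.76 log units; beyond the scatter), a lower number is expected in this assay, though probably a smaller step, since propyl is the shorter addition. The expected result is an at least 6.4-fold lower number from compound 3 to compound 4 (0.80 log units; beyond the scatter). A reading that again gives only a limit remains possible. For compound 4 the estimated value is 20000 nM, with an expected range from 5000 nM to 100000 nM.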

Compound 4, half-maximal inhibitory concentration: 45000 nM
Estimate against measurement, compound 4: 2.3-fold (0.35 log units) below; measured number inside the range.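

In this assay, propyl in place of hydrogen on a saturated chain carbon, seven bonds along the chain from an aromatic nitrogen, gives a readable step in the configuration of compound 3 as well: an at least 2.8-fold lower number from compound 3 to compound 4 (0.45 log units; beyond the scatter). Compound 3 gives > 128000 nM, which is a limit and not a number. The earlier chain step, an at least 57-fold lower number from compound 1 to compound 2 (1.76 log units; beyond the scatter), was seen with pentyl in the configuration of compound 1 only, so the lower number on adding chain carbons now holds in both configurations shown, with no listed compound against it.

The effect of configuration alone stays unread: the step from compound 1 to compound 3 cannot be read, and compound 2 at 2210 nM and compound 4 at 45000 nM differ in two places, so they give no clean comparison. Also open, from the compounds shown here alone, is whether a chain longer than that of compound 2, or an amine or a carboxylic acid carried on the chain, would keep this direction in this assay in either configuration.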